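From Compound 3 to Compound 4: A Small Change Expected

A few compounds are considered here, and "the series" means these few. Any claim that something is new, unique, unknown or untested is made for them only; others in the source may bear on it.

Of the compounds shown here, three have been measured in an assay on isolated protein (Cavia porcellus) with Sigma non-opioid intracellular receptor 1 (Homo sapiens) as the target, read by radioligand binding; a lower number here means a stronger inhibitor, a higher number a weaker inhibitor: compound 1, `O=c1cc(-c2ccccc2)oc2cccc(OCCCCN3CCC(O)CC3)c12`, compound 2, `O=c1cc(-c2ccccc2)oc2ccc(OCCCCCCN3CCCC(O)C3)cc12`, and compound 3, `O=c1cc(-c2ccccc2Cl)oc2ccc(OCCCCCCN3CCC(O)CC3)cc12`. Compound 1 gives 58 nM, compound 2 gives 86 nM and compound 3 gives 47 nM. Compound 3 holds the lowest of the three numbers, yet its gaps to compound 1 and to compound 2 both lie within the scatter, so no order among them can be claimed. Compound 4, `COc1cccc(-c2cc(=O)c3cc(OCCCCCCN4CCC(O)CC4)ccc3o2)c1`, has not yet been measured. It differs from compound 3 in one place: 3-methoxyphenyl in place of 2-chlorophenyl on an aromatic carbon. For the measured compounds named here, no measured pair isolates this change, so its direction cannot be read from the data. The expected step in this assay is a 1.3-fold higher number from compound 3 to compound 4 (0.11 log units; within the scatter), a shift that would stay within the scatter. Compound 4 is estimated at 60 nM, with a range from 25 nM to 150 nM.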

Compound 4, half-maximal inhibitory concentration: 76 nM
Estimate against measurement, compound 4: 1.3-fold (0.10 log units) below; measured number inside the range.
By their numbers in this assay, from the lowest: compounds 3, 1, 4 and 2 (each within the scatter of the next).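

In this assay, replacing 2-chlorophenyl with 3-methoxyphenyl gives a 1.6-fold higher number from compound 3 to compound 4 (0.21 log units; within the scatter), the first step read at this position of the shared core. This step lies within the scatter, so the two groups cannot be told apart here, although the swap alters both the substituent and its place on the phenyl ring. Nothing available bears on the reason for this result. Those two alterations remain unseparated, since neither 2-methoxyphenyl nor 3-chlorophenyl is among the compounds shown. As far as these compounds go, whether an amine or a carboxylic acid on that phenyl ring would give a step beyond the scatter also stays open.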